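The source may report more compounds than this note shows. Statements on the series, on what has been measured and on what is new or still open speak of the compounds shown alone.

Measured compounds in an assay on isolated protein for inhibition of aldehyde dehydrogenase 1A1 (Homo sapiens), read by spectrophotometry, tested at 10 uM; on this read-out higher numbers stand for more inhibition at the one concentration tested (going by the name of the read-out) and lower numbers for less inhibition:
- compound 1 `Cc1cccc(Cn2c(OC3CCN(C(=O)c4ccco4)CC3)nc3ccccc32)c1` gives 68.3%
- compound 2 `Cc1cccc(Cn2c(CN3CCN(C(=O)C4CCCCC4)CC3)nc3ccccc32)c1` gives 31.9%
- compound 3 `CC(C)CCn1c(OC2CCN(C(=O)C3CC3)CC2)nc2ccccc21` gives 56.4%

Among these three, compound 2 stands lowest: compound 3 lies beyond the scatter above it, and compound 1 further still. Compound 4 `Cc1cccc(Cn2c(CN3CCN(C(=O)c4ccco4)CC3)nc3ccccc32)c1` has not been tested in this assay. It differs from compound 2 in one place: furan-2-yl in place of cyclohexyl on a carbonyl carbon, a swap of cyclohexylcarbonyl for (furan-2-yl)carbonyl on the carbonyl carbon next to the amide-type nitrogen in a ring. Among the compounds with values here, no measured pair shows this exact exchange, so the expected size rests only on compound 1, which carries the same furan-2-yl group and reaches 68.3%, though on a different linker. A moderate rise is expected for compound 4, as a number 13.1 percentage points higher from compound 2 to compound 4 (beyond the scatter), giving an estimated 45% within 22% to 68%.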

Compound 4, a percentage reported as inhibition, at one concentration (the size of the read-out at that concentration, not a potency): 73.2%
Compound 4: middle estimate off by 28.2 percentage points, on the low side; measured number outside the range, above it.
By their numbers in this assay, from the lowest: compound 2; then compound 3; then compounds 1 and 4 (each within the scatter of the next).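

In this assay, the step of a number 41.3 percentage points higher from compound 2 to compound 4 (beyond the scatter) comes from furan-2-yl in place of cyclohexyl on a carbonyl carbon, so the group at this position strongly affects inhibition. Within the data shown here, this exchange is the first seen with the rest of the molecule unchanged, which ties the step to this one place. Nothing measured here explains why the step is so large.

From the compounds shown here alone, whether phenyl or thiophen-2-yl on the same carbonyl carbon would match furan-2-yl remains open. So does whether the same exchange would give a similar step in compound 3, which carries cyclopropyl there.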